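From oxetan-3-yl to oxetan-2-yl: a solubility question

The compounds below may be only part of what the source reports. "The series", "measured", "known", "first", "only" and "open" are said of these compounds alone.

Of the compounds shown here, two have so far been tested in a physicochemical assay for solubility, read by chemiluminescence, measured as kinetic solubility; on this read-out lower numbers stand for lower solubility and higher numbers for higher solubility. Compound 1 `CC(=O)NCc1cccc(Cn2nc(NS(=O)(=O)c3ccc(Cl)s3)c3c(C(F)F)cccc32)c1` gives >= 188 ug/mL, which is a limit and not an exact number. Compound 2 `COc1cccc2c1c(NS(=O)(=O)c1ccc(Cl)s1)nn2Cc1cccc(CNC(=O)C2COC2)c1` gives >= 173 ug/mL, which is also a limit. Compound 2 therefore stands at a limit of this assay, and no exact value is available for either compound. Compound 3 `COc1cccc2c1c(NS(=O)(=O)c1ccc(Cl)s1)nn2Cc1cccc(CNC(=O)C2CCO2)c1` has the same atoms as compound 2, joined differently: oxetan-2-yl in place of oxetan-3-yl on a carbonyl carbon. Oxetan-2-yl takes the place of oxetan-3-yl on a carbonyl carbon. For the measured compounds named here, no measured pair shows what this change does, so the expectation rests only on compound 2 and its limit of >= 173 ug/mL. The expected step in this assay has no favoured direction and is no larger than the usual scatter: an at least 1.0-fold lower number from compound 2 to compound 3 (0.00 log units; that floor lies within the scatter). For compound 3 the estimated solubility is 170 ug/mL, with an expected range from 85 ug/mL to 200 ug/mL.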

Compound 3, solubility: 124 ug/mL
Estimate against measurement, compound 3: 1.4-fold (0.14 log units) above; low and high end bracket the measured number.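

For the compounds shown here, compound 3 gives the first exact number in this assay, where the earlier compounds offered only limits, so this place on a carbonyl carbon now has a firm reference point. Oxetan-2-yl in place of oxetan-3-yl, the same atoms joined differently, gives an at least 1.3-fold lower number from compound 2 to compound 3 (0.14 log units; that floor lies within the scatter), so nothing beyond the scatter can be claimed for this change, although the real gap could be larger than that floor. The step can be stated only as a floor because the number for compound 2 is a limit: the limit of >= 173 ug/mL in this assay, at which 1 of the 3 values shown sits.

On these data alone, how far the real gap runs past that floor remains open. Also open, as far as these compounds go, is how an amine such as azetidin-3-yl, or an open chain such as methoxymethyl, would behave on the same carbonyl carbon.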